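Thiadiazole in place of tetrazole: expected cytotoxicity of compound 3

The compounds below may be only part of what the source reports. "The series", "measured", "known", "first", "only" and "open" are said of these compounds alone.

Compound 1 `Cc1nnc(SCC(=O)N/N=c2/scc(-c3ccc(Cl)cc3)n2-c2ccccc2)s1`: 253 ug/mL
Compound 2 `Cc1ccc(-c2cs/c(=N/NC(=O)CSc3nnnn3C)n2-c2ccccc2)cc1`: 243 ug/mL

In an ADME assay on NIH3T3 cells (Mus musculus) for cytotoxicity, read by MTT assay, with a stated time of 24 h (on this read-out lower numbers stand for stronger inhibition and higher numbers for weaker inhibition), compound 2 gives 243 ug/mL, and compound 1 gives 253 ug/mL; the two sit within the scatter of each other, so compound 2 cannot be set apart from compound 1 on these numbers. Compound 3 `Cc1ccc(-c2cs/c(=N/NC(=O)CSc3nnc(C)s3)n2-c2ccccc2)cc1` differs from compound 2 by 5-methyl-1,3,4-thiadiazol-2-yl in place of 1-methyl-1H-tetrazol-5-yl on a sulfur. For the measured compounds named here, no measured pair shows this change on its own. Compound 1 already carries the entering group and shows no separation from compound 2, so the step from compound 2 to compound 3 is expected to be a 1.0-fold higher number from compound 2 to compound 3 (0.01 log units; within the scatter), within the scatter. Compound 3 is therefore estimated at 250 ug/mL, with a range from 130 ug/mL to 480 ug/mL.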

Compound 3, half-maximal inhibitory concentration: 373 ug/mL
Compound 3: the middle estimate sits 1.5-fold (0.17 log units) below what was measured, and the stated range covers the measured number.
By their numbers in this assay, from the lowest: compounds 2, 1 and 3 (each within the scatter of the next).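

In this assay, 5-methyl-1,3,4-thiadiazol-2-yl in place of 1-methyl-1H-tetrazol-5-yl on a sulfur now has a measured pair of its own, showing a 1.5-fold higher number from compound 2 to compound 3 (0.19 log units; within the scatter), which is within the scatter. With 5-methyl-1,3,4-thiadiazol-2-yl kept, methyl in place of chloro on an aromatic carbon gives a 1.5-fold higher number from compound 1 to compound 3 (0.17 log units; within the scatter), also within the scatter, so neither change separates the compounds on these numbers. On these data alone, whether an amine or a carboxylic acid in place of these rings on the sulfur would move the number beyond the scatter stays open. Nothing at hand bears on what lies behind these steps.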